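This account rests on a few compounds, and the source may have more. Where it says the series, first, only, none or still open, it means among the compounds named here.

Working notes on the series, read in a functional assay on CCRF-CEM cells (Homo sapiens) for cytotoxicity, in the presence of a further agent that is not named here; a higher number here means a weaker inhibitor, a lower number a stronger inhibitor. In this assay compound 1 (`COC(=O)c1ccc(CN(CCCc2c(N)nc(N)nc2O)c2cc(F)cc(F)c2[N+](=O)[O-])cc1`) gives > 100000 nM, which is a limit and not a number. Compound 2 (`Nc1nc(N)c(CCCN(Cc2ccc(NC(CCC(=O)O)C(=O)O)cc2)c2cc(F)c(F)cc2[N+](=O)[O-])c(O)n1`) gives > 100000 nM, also a limit. Compound 3 (`Nc1nc(N)c(CCCN(Cc2ccc(NC(CCC(=O)O)C(=O)O)cc2)c2ccc([N+](=O)[O-])c(F)c2F)c(O)n1`) gives > 100000 nM, again a limit, so it stands with the other two: the limit of > 100000 nM in this assay, at which 3 of the 3 values shown sit.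

Compound 4 (`Nc1nc(N)c(CCCN(Cc2ccc(NC(CCC(=O)O)C(=O)O)cc2)c2cc(F)cc(F)c2[N+](=O)[O-])c(O)n1`) comes next, with the change (3,5-difluoro-2-nitrophenyl in place of 2,3-difluoro-4-nitrophenyl on an amine nitrogen). The two have the same atoms, and only the difluoronitrophenyl group on the amine nitrogen is exchanged. For the measured compounds named here, the one measured step of this type, a step that the two limits leave unreadable from compound 2 to compound 3, also swaps one difluoronitrophenyl group for another, but it gives no size to carry over. No step beyond the scatter is therefore expected in this assay, no direction can be assigned, and another limit reading is the likeliest result. The expected step is a number no higher from compound 3 to compound 4 (the limit leaves the size open). For compound 4 the estimate is 100000 nM, with an expected range of 30000 nM to 200000 nM.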

Compound 4, half-maximal inhibitory concentration: > 100000 nM
Compound 4 ended at the assay's limit; the forecaster's own chance of this, stated with the estimate: 85%; the middle value sits exactly at the limit.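

In this assay compound 4 gives > 100000 nM, a limit. For the compounds shown here, no step from compound 1, compound 2 or compound 3 to compound 4 can be read. The compounds shown leave open whether exchanging the difluoronitrophenyl or methoxycarbonyl group shifts the read-out at all, with every value at one place: the limit of > 100000 nM in this assay, at which 4 of the 4 values shown sit.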